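Sulfonamide anilides: aryl to styryl amide swap

The source may hold more compounds than are shown below. What is called first, only, known or untested is meant among the compounds shown, and "the series" means these compounds.

Working notes on the cytotoxicity series, read in a functional assay on C8166 cells (Homo sapiens) for cytotoxicity, read by MTT assay; a lower number here means that less compound is tolerated, a higher number that more compound is tolerated. Compound 1 `Cc1cc(S(N)(=O)=O)ccc1NC(=O)COc1ccc(Cl)cc1NC(=O)c1ccccc1C` gives 67300 nM in this assay. Compound 2 `Cc1ccc(C)c(C(=O)Nc2cc(Cl)ccc2OCC(=O)Nc2ccc(S(N)(=O)=O)cc2C)c1` gives 79700 nM, the highest of the two numbers, with the step being a 1.2-fold higher number from compound 1 to compound 2 (0.07 log units; within the scatter). Compound 3 `Cc1cc(S(N)(=O)=O)ccc1NC(=O)COc1ccc(Cl)cc1NC(=O)/C=C/c1ccccc1` carries 2-phenylethenyl in place of 2,5-dimethylphenyl on a carbonyl carbon. Among the compounds with values here, the single measured step concerns a different group and stayed within the scatter, so it gives no footing for a shift here; the expectation is no step beyond the scatter, a 1.1-fold lower number from compound 2 to compound 3 (0.03 log units; within the scatter). Compound 3 is therefore estimated at 75000 nM, in the range 35000 nM to 160000 nM.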

Compound 3, half-maximal cytotoxic concentration: 163000 nM
Compound 3: the middle estimate sits 2.2-fold (0.34 log units) below what was measured; the measured number lies above the stated range.
By their numbers in this assay, from the lowest: compounds 1 and 2 (each within the scatter of the next); then compound 3.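

Within the data shown here, at the carbonyl carbon, in this assay, the change to 2-phenylethenyl gives a 2.0-fold higher number from compound 2 to compound 3 (0.31 log units; beyond the scatter) and a 2.4-fold higher number from compound 1 to compound 3 (0.38 log units; beyond the scatter), both modest but the first steps beyond the scatter. This position therefore responds to replacing the directly attached aryl group, whereas adding a methyl to that aryl group did not move the number beyond the scatter. No available evidence accounts for the shift.

On these data alone, it remains open whether the double bond matters, which a saturated 2-phenylethyl group would test. Also open, as far as these compounds go, is how an amine or carboxylic acid on the phenyl ring would read.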